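The source may hold more compounds than are shown below. What is called first, only, known or untested is meant among the compounds shown, and "the series" means these compounds.

Measured compounds in a functional assay (aorta) with Rattus norvegicus as the target; on this read-out higher numbers stand for an effect only at larger amounts of compound and lower numbers for an effect already at smaller amounts:
Compound 1 `O=S1(=O)N=C(NCc2ccccc2)Nc2ncccc21` gives 21.9 uM.
Compound 2 `C[C@H](NC1=NS(=O)(=O)c2cccnc2N1)c1ccccc1` gives 65.2 uM.
Compound 3 `CC(C)NC1=NS(=O)(=O)c2cc(Cl)cnc2N1` gives 14.6 uM.

Compound 1 and compound 2 differ in one place, (methyl in place of hydrogen on a saturated chain carbon bound to an amine nitrogen and an aromatic carbon), and that change made a 3.0-fold higher number from compound 1 to compound 2 (0.47 log units; beyond the scatter). Compound 3 resembles compound 1, but the difference between the two cores is not broken down here; the values of compound 3 and compound 1 lie within the usual scatter of each other. Compound 4 `CCC(C)NC1=NS(=O)(=O)c2cc(Cl)cnc2N1` has not yet been measured. It differs from compound 3 by methyl in place of hydrogen on a saturated chain carbon, two bonds along the chain from an amine nitrogen. This is the same kind of change as that from compound 1 to compound 2, yet not the same: there the methyl entered on a saturated chain carbon bound to an amine nitrogen and an aromatic carbon, here it enters on a saturated chain carbon, two bonds along the chain from an amine nitrogen. Among the compounds with values here, the expectation rests on a 3.0-fold higher number from compound 1 to compound 2 (0.47 log units; beyond the scatter), the only such step known, and on the different place, which weakens the comparison. For compound 4 a smaller step is expected, about a 1.7-fold higher number from compound 3 to compound 4 (0.23 log units; within the scatter). Compound 4 is thus estimated at 25 uM in this assay, with a likely range from 10 uM to 60 uM.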

Compound 4, concentration for half-maximal effect: 20 uM
For compound 4 the middle estimate is 1.3-fold (0.10 log units) above the measured one; measured number inside the range.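

In this assay, the added methyl gave a 1.4-fold higher number from compound 3 to compound 4 (0.14 log units; within the scatter). Set beside the earlier step, this one does not differ from it by more than repeated measurements can account for: the same change on two cores in this assay, a 3.0-fold higher number (0.47 log units; beyond the scatter) from compound 1 to compound 2 and a 1.4-fold higher number (0.14 log units; within the scatter) from compound 3 to compound 4, 2.2-fold (0.34 log units) apart, within the scatter of two such steps

Within the data shown here, this does not prove that the change carries over unchanged from one core to the other: only two steps exist, the methyl enters at a different place in each, and only the earlier step lies beyond the scatter. As far as these compounds go, it remains open how the number in this assay would respond to a longer chain in place of sec-butyl. An amine or a carboxylic acid on that chain is also untested among the compounds shown here.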